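A Longer Chain on a Core That Shows Only Limits

The source may hold more compounds than are shown below. What is called first, only, known or untested is meant among the compounds shown, and "the series" means these compounds.

Compound 1, `CCCc1nc(C)c2c(C(C)C)nnc(O)n12`: in a functional assay for inhibition, with Homo sapiens as the target (a higher number here means a weaker inhibitor, a lower number a stronger inhibitor), compound 1 gives > 48000 nM, a limit of the assay.
Compound 2, `Cc1nc(C)n2c(O)nncc12`: in this assay compound 2 gives > 48000 nM, a limit of the assay.
Compound 3, `CCc1nnc(O)n2c(C)nc(C)c12`: in this assay compound 3 gives > 48000 nM, a limit of the assay.

Compound 3 stands at the limit of this assay; its value is a limit, not a number. The same holds for the other two compounds, as the limit of > 48000 nM in this assay, at which 3 of the 3 values shown sit, records. For the measured compounds named here, the one step between measured compounds, a step that the two limits leave unreadable from compound 2 to compound 3, has a limit at both of its ends and so cannot be read in size.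

Compound 4, `CCCc1nc(C)c2c(CC)nnc(O)n12`, differs from compound 3 by ethyl in place of hydrogen on a saturated chain carbon bound to an aromatic carbon. Going by the values given here, no measured step bears on this change in a readable way: the step from compound 2 to compound 3 also adds an ethyl, but its size stays hidden behind the two limits. With three of three values sitting at the limit, compound 4 is expected to remain there as well, and the expected step that the limit leaves unreadable from compound 3 to compound 4 is one the assay would not reveal. Compound 4 is therefore estimated at 70000 nM in this assay, within a range from 20000 nM to 250000 nM.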

Compound 4, half-maximal inhibitory concentration: 15600 nM
Compound 4: the middle estimate sits 4.5-fold (0.65 log units) above what was measured; measured number below the stated range.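

In this assay, for the compounds shown here, the change from methyl to propyl, ethyl in place of hydrogen on a saturated chain carbon bound to an aromatic carbon, gives an at least 3.0-fold lower number from compound 3 to compound 4 (0.48 log units; beyond the scatter), so this position responds to a longer chain in a way that the earlier compounds, all held at a limit, could not show. A second change, elsewhere on the shared core, also matters: hydrogen in place of methyl on a saturated chain carbon bound to an aromatic carbon and a saturated chain carbon gives an at least 3.0-fold lower number from compound 1 to compound 4 (0.48 log units; beyond the scatter). Compound 4, which carries the propyl together with the unbranched ethyl, is thus the only compound shown to leave the limit: the limit of > 48000 nM in this assay, at which 3 of the 4 values shown sit.

On these data alone, each of the two steps has a limit at one end, so its true size remains unknown, and neither step shows how far the number could fall at these positions. As far as these compounds go, whether a longer chain such as butyl, or an amine at the end of the propyl chain, would lower the number further in this assay also remains open.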